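The source may report more compounds than this note shows. Statements on the series, on what has been measured and on what is new or still open speak of the compounds shown alone.

Measured compounds:
- compound 1 `O=C(Nc1ccc(Cl)c(-c2nnc3c(Cl)cccn23)c1)c1ccccc1`, which in a functional assay on HeLa cells (Homo sapiens) for antiproliferative activity, read by MTT assay, with a stated time of 72 h (on this read-out higher numbers stand for weaker inhibition and lower numbers for stronger inhibition), gives > 100000 nM, a limit of the assay rather than a number.
- compound 2 `Cc1cc(Cl)ccc1C(=O)Nc1ccc(Cl)c(-c2nnc3c(Cl)cccn23)c1`, which in this assay gives > 100000 nM, again a limit of the assay.

Compound 1 therefore stands at the top of the measured range, with only a limit and no number to its name. Among the measured compounds shown here, the single measured step, a step that the two limits leave unreadable from compound 1 to compound 2, runs between two limits and so cannot be read for size or direction; what both values show is summed up in the limit of > 100000 nM in this assay, at which 2 of the 2 values shown sit. The new compound 3 `O=C(Nc1ccc(Cl)c(-c2nnc3c(Cl)cccn23)c1)c1cccnc1` differs from compound 1 by pyridin-3-yl in place of phenyl on a carbonyl carbon. For the measured compounds named here, no measured step covers a change of this kind, and the only neighbouring change gave no readable step. Compound 3 is therefore expected to remain at or near the limit, with the step of a number no higher from compound 1 to compound 3 (the limit leaves the size open) estimated as none beyond the scatter. For compound 3 the estimate is 100000 nM, within 30000 nM to 300000 nM.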

Compound 3, half-maximal inhibitory concentration: > 100000 nM
Compound 3: a limit, no number; the forecaster's own chance of this, stated with the estimate: 80%; the middle value lies on the limit itself.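

No step can be read among compound 1, compound 2 and compound 3, because each value is a limit of the assay and not a number: the limit of > 100000 nM in this assay, at which 3 of the 3 values shown sit. Which change to the shared core, if any, would give a measurable number in this assay stays open.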